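A few compounds are considered here, and "the series" means these few. Any claim that something is new, unique, unknown or untested is made for them only; others in the source may bear on it.

Compound 2 `CC(C(=O)N1CCN(c2cccc(F)c2)CC1)N1C(=O)CCC1=O` gives 0% in a functional assay on the whole organism (strain Swiss) with Mus musculus as the target, in the maximal electroshock model, with a stated time of 2 h, at a dose of 100 mg/kg by the intraperitoneal route (on this read-out lower numbers stand for a weaker effect and higher numbers for a stronger effect at the one dose given), level with compound 1 `COc1cccc(N2CCN(C(=O)C(C)N3C(=O)CCC3=O)CC2)c1`, which gives 0% in this assay. For the measured compounds named here, the one step between them, no change at the digits printed from compound 1 to compound 2 (within the scatter), stayed within the scatter. Compound 3 `Cc1cccc(N2CCN(C(=O)C(C)N3C(=O)CCC3=O)CC2)c1` differs from compound 2 by methyl in place of fluoro on an aromatic carbon. Going by the values given here, no measured step swaps fluoro for methyl, so only the flat step from compound 1 to compound 2 offers any guide, and it points to no movement. Compound 3 is therefore expected to show a step of no change at the digits printed from compound 2 to compound 3 (within the scatter), that is, none beyond the scatter. The estimate for compound 3 is 0%, between 0% and 20%.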

Compound 3, a percentage reported as activity, at one dose (the size of the read-out at that dose, not a potency): 0%
Beside the measured number, compound 3's estimate shows no gap at the digits printed; the range from low to high includes it.
By their numbers in this assay, from the lowest: compounds 1, 2 and 3 (each within the scatter of the next).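

In this assay the swap of 3-fluorophenyl to 3-methylphenyl gives (no change at the digits printed from compound 2 to compound 3 (within the scatter)), and methyl in place of methoxy gives (no change at the digits printed from compound 1 to compound 3 (within the scatter)). Methoxy, fluoro and methyl on this aromatic carbon therefore all read alike, whereas the earlier compounds compared only methoxy and fluoro. No available evidence explains this flat result. All three compounds sit at the bottom of the read-out, so a change that lowers the effect could not be seen here. From the compounds shown here alone, whether an amine, a carboxylic acid or a longer chain such as propyl at this place would produce any effect stays open.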